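Methoxy in Place of Fluoro on a Weak Sulfone

A few compounds are considered here, and "the series" means these few. Any claim that something is new, unique, unknown or untested is made for them only; others in the source may bear on it.

Compound 1 `COc1ccc(/C=C/S(=O)(=O)Cc2ccc(OC)cc2)cc1` and compound 2 `COc1ccc(CS(=O)(=O)/C=C/c2ccc(F)cc2OC)cc1` share a core in which two aromatic rings are joined through a sulfone and a double bond. In a functional assay on DLD-1 cells (Homo sapiens) for antiproliferative activity, read by trypan blue exclusion (a higher number here means a weaker inhibitor, a lower number a stronger inhibitor), compound 1 reaches only the limit of the assay, > 20000 nM, and no number is obtained. In this assay, among the compounds with values here, compound 2 gives 15000 nM, which is the only actual number among the values shown. The other entry is the limit of > 20000 nM in this assay, at which 1 of the 2 values shown sits. Both compounds therefore sit at the weak end of what the assay can report.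

Compound 3 `COc1ccc(CS(=O)(=O)/C=C/c2ccc(OC)cc2OC)cc1` is built from compound 2 by methoxy in place of fluoro on an aromatic carbon. Within the data shown here, no step between two measured compounds is available, so the effect of this exchange cannot be read from an earlier example. The change is expected to move the number little, if at all, beyond the usual scatter of the assay, amounting to a 1.1-fold higher number from compound 2 to compound 3 (0.03 log units; within the scatter). On that basis compound 3 is estimated at 16000 nM in this assay, with a range from 6000 nM to 40000 nM.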

Compound 3, half-maximal inhibitory concentration: > 20000 nM
Compound 3 ended at the assay's limit; the forecaster's own chance of this, stated with the estimate: 35%; at least 1.2-fold (0.09 log units) between middle value and limit.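

In this assay, methoxy in place of fluoro on this aromatic carbon, para to a large group, shows no sign of a gain: the exchange gives an at least 1.3-fold higher number from compound 2 to compound 3 (0.12 log units; that floor lies within the scatter), and only this floor is known, so the real size of the step stays hidden. Methoxy at this place therefore leaves the compound at the weak end of the assay, and it adds no usable number to the set. The step from hydrogen to methoxy, from compound 1 to compound 3, cannot be read, as both of its ends are limits, and the set now offers few numbers for any comparison: the limit of > 20000 nM in this assay, at which 2 of the 3 values shown sit.

On these data alone, it stays open how far past the limit compound 3 lies, and so whether the exchange costs little or much. As far as these compounds go, it also stays open whether an amine or a carboxylic acid on this same carbon would bring a number well clear of the limit in this assay, or whether this position has little influence on the result at all.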